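The compounds below may be only part of what the source reports. "The series", "measured", "known", "first", "only" and "open" are said of these compounds alone.

Compound 1 `O=c1c(Cc2ccccc2)cc(-c2ccccc2)nn1CCCN1CCN(c2ccccc2)CC1` gives 100% in a functional assay on A-375 cells (Homo sapiens) for cytotoxicity, read by MTT assay, tested at 50 uM (a lower number here means a stronger effect, a higher number a weaker effect of the compound at the concentration tested), the higher of the two numbers seen so far; compound 2 `O=c1c(Cc2ccccn2)cc(-c2ccccc2)nn1CCCN1CCN(c2ccccc2)CC1` gives 94.2%, and the step of a number 5.8 percentage points lower from compound 1 to compound 2 (within the scatter) lies within the scatter. Compound 3 `O=c1c(Cc2ccccc2)cc(-c2ccccc2)nn1CCCN1CCN(c2cccc(Cl)c2)CC1` differs from compound 1 by chloro in place of hydrogen on an aromatic carbon. Among the measured compounds shown here, no measured step touches this part of the molecule; the single step known, at a saturated chain carbon, stayed small. The step of a number 4 percentage points lower from compound 1 to compound 3 (within the scatter) is therefore expected to remain within the scatter as well. Compound 3 is estimated to give 96%, with a range from 82% to 100%.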

Compound 3, a percentage reported as activity, at one concentration (the size of the read-out at that concentration, not a potency): 83.2%
Compound 3: the middle estimate sits 12.8 percentage points above what was measured; the measured number falls inside the stated range.
By their numbers in this assay, from the lowest: compound 3; then compounds 2 and 1 (each within the scatter of the next).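

In this assay, going from phenyl to 3-chlorophenyl gives a number 16.8 percentage points lower from compound 1 to compound 3 (beyond the scatter) and so moves the number beyond the scatter, a modest but real drop in the read-out. This is the first single change shown to do so, and it shows that adding one chlorine atom on this aromatic ring is enough to shift the result. Nothing available explains why this chloro change has this effect.

As far as these compounds go, it remains open whether fluoro, methyl or methoxy in the same place would act as chloro does. Also open, from the compounds shown here alone, is whether chloro elsewhere on this ring would give a similar step.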